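The compounds below may be only part of what the source reports. "The series", "measured", "known", "first", "only" and "open" are said of these compounds alone.

Compound 1 (`CNC(=O)c1cc(C(=O)NCCC2CCOCC2)cn(Cc2ccccc2)c1=O`) is the starting point of this step. In a physicochemical assay for solubility (on this read-out higher numbers stand for higher solubility and lower numbers for lower solubility), compound 1 gives >= 127 ug/mL as a limit of the assay and not a number. Its place on the scale is thus the limit of >= 127 ug/mL in this assay, at which 1 of the 2 values shown sits, in the data so far. Among the measured compounds shown here, the only other value belongs to compound 2 (`CNC(=O)c1cc(C(=O)NC2CC2)cn(Cc2cccc3[nH]ncc23)c1=O`), which reads 10 ug/mL in this assay and offers no measured step, since none links two measured compounds. Compound 3 (`CNC(=O)c1cc(C(=O)NCCO)cn(Cc2ccccc2)c1=O`) has hydroxy in place of oxan-4-yl on a saturated chain carbon, two bonds along the chain from an amide-type nitrogen. A small rise in this assay is expected, perhaps none beyond the scatter, and another limit reading is possible. The expected move is a step that the limit leaves unreadable from compound 1 to compound 3 as an estimate only. For compound 3 the estimated value is 170 ug/mL within an expected range of 70 ug/mL to 400 ug/mL for now.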

Compound 3, solubility: >= 140 ug/mL
Compound 3: a limit, no number; the forecaster's own chance of this, stated with the estimate: 55%; the middle value is on the limit's open side.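

Among the compounds shown here, compound 1 and compound 3 both stand as limits in this assay and not as numbers, and no step between them can be read. Still open, as far as these compounds go, is what number either compound would give, and whether hydroxy in place of oxan-4-yl shifts this assay at all.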